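A few compounds are considered here, and "the series" means these few. Any claim that something is new, unique, unknown or untested is made for them only; others in the source may bear on it.

Measured in a functional assay on MDA-MB-231 cells (Homo sapiens) for antiproliferative activity, read by MTT assay, with a stated time of 72 h; on this read-out higher numbers stand for weaker inhibition of growth and lower numbers for stronger inhibition of growth:
- Compound 1 `Cc1c(C(=O)Nc2ccc(SC#N)cc2)nnn1-c1ccc(C(C)C)cc1`: > 100000 nM
- Compound 2 `Cc1ccc(Cl)c(-n2nnc(C(=O)Nc3ccc(SC#N)cc3)c2C)c1`: > 100000 nM

Compound 2 stands at > 100000 nM, which is a limit of the assay and not a number. Compound 1 likewise gives only a limit, > 100000 nM. Compound 3 `COc1cccc(-n2nnc(C(=O)Nc3ccc(SC#N)cc3)c2C)c1` carries 3-methoxyphenyl in place of 2-chloro-5-methylphenyl on an aromatic nitrogen. For the measured compounds named here, the one measured change at this place, a step that the two limits leave unreadable from compound 1 to compound 2, gives no size, and the record there is the limit of > 100000 nM in this assay, at which 2 of the 2 values shown sit. With no readable step to build on, little growth inhibition is expected here, and another limit is likely. The expected step is a number no higher from compound 2 to compound 3 (the limit leaves the size open). Compound 3 is estimated at 100000 nM, within an expected range of 30000 nM to 300000 nM.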

Compound 3, concentration for 50% growth inhibition: > 100000 nM
Compound 3 gave a limit, no number; the forecaster's own chance of this, stated with the estimate: 70%; the middle value sits exactly at the limit.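

Compound 1, compound 2 and compound 3 each give only a limit of the assay in this assay, so no step among them can be read: the limit of > 100000 nM in this assay, at which 3 of the 3 values shown sit.

The compounds shown leave open whether any group at this place on the aromatic nitrogen gives a measurable inhibition of growth.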